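The source may report more compounds than this note shows. Statements on the series, on what has been measured and on what is new or still open speak of the compounds shown alone.

Compound 1 `CCCCCNC(=O)/N=C(\N)NCCCc1sc(N)nc1C` gives 178 nM in a functional assay on HEK293T cells for agonist activity at histamine H2 receptor (Homo sapiens), read by beta-arrestin recruitment (a higher number here means that more compound is needed for the effect, a lower number that less compound is needed), the lower of the two numbers in hand; compound 2 `Cc1nc(N)sc1CCCN/C(N)=N/C(=O)NCC(C)CCc1ccccc1` gives 355 nM in this assay, and the two values lie within the scatter of each other. Compound 3 `Cc1nc(N)sc1CCCN/C(N)=N/C(=O)NC(C)c1ccco1` is not yet measured and differs from compound 1 as 1-(furan-2-yl)ethyl in place of pentyl on an amide-type nitrogen. Among the measured compounds shown here, no step between measured compounds carries this change. Since compound 2 already sits within the scatter of compound 1, no step beyond the scatter is expected, any shift most likely toward a higher number. For compound 3 the expected value in this assay is 250 nM, range 100 nM to 650 nM. The expected step is a 1.4-fold higher number from compound 1 to compound 3 (0.15 log units; within the scatter).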

Compound 3, half-maximal effective concentration: 234 nM
Beside the measured number, compound 3's estimate is 1.1-fold (0.03 log units) above it; the range from low to high includes it.
By their numbers in this assay, from the lowest: compounds 1, 3 and 2 (each within the scatter of the next).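

On the amide-type nitrogen, 1-(furan-2-yl)ethyl in place of pentyl gives a 1.3-fold higher number from compound 1 to compound 3 (0.12 log units; within the scatter) in this assay. This first one-place step in the series shows that this position accepts a five-membered aromatic ring with a hydrogen-bond acceptor in place of an open chain, with the step staying within the scatter. Nothing on hand gives a reason for this result. Open, from the compounds shown here alone, is whether the furan oxygen or the methyl on the linking carbon matters here: furan-2-ylmethyl and 1-phenylethyl would separate the two. Going by these compounds, a terminal amine or carboxylic acid on the pentyl chain also remains open.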